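Swapping the Charged Ring at the End of the Side Chain

The source may report more compounds than this note shows. Statements on the series, on what has been measured and on what is new or still open speak of the compounds shown alone.

Compound 1 `Cc1cc(OCCCCCCC[N+]23CCN(CC2)CC3)cc(-n2cc(C(=O)Nc3cc(F)cc(F)c3)c(=O)c3ccc(N(C)C)nc32)c1`: 10.3%
Compound 2 `Cc1cc(OCCCCCCC[N+]2(C)CCCC2)ccc1-n1cc(C(=O)Nc2cc(F)cc(F)c2)c(=O)c2ccc(N(C)C)nc21`: "not active" (no number reported)
Compound 3 `CN(C)c1ccc2c(=O)c(C(=O)Nc3cc(F)cc(F)c3)cn(-c3ccc(OCCCCCCC[N+]4(C)CCCC4)cc3Cl)c2n1`: "not active" (no number reported)

Going by the values given here, in an assay on LX2 cells for inhibition of COL1A1 promoter (Homo sapiens), read by a luciferase reporter, with a stated time of 24 h, tested at 20 uM (on this read-out higher numbers stand for a stronger effect at the one concentration tested and lower numbers for a weaker effect), compound 1 gives 10.3%, a weak effect at the single concentration tested, yet it is the only number in this set. Compound 2 and compound 3, which carry a different charged ring at the end of the chain, were recorded as not active without a number.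

Compound 4 `Cc1cc(OCCCCCCC[N+]2(C)CCCC2)cc(-n2cc(C(=O)Nc3cc(F)cc(F)c3)c(=O)c3ccc(N(C)C)nc32)c1` differs from compound 1 by a group of 6 heavy atoms (5 carbon, 1 nitrogen; one five-membered non-aromatic ring with 1 hetero atom) in place of a group of 8 heavy atoms (6 carbon, 2 nitrogen; 2 six-membered non-aromatic rings with 2 hetero atoms each), on a saturated chain carbon, seven bonds along the chain from an oxygen on an aromatic ring. Among the compounds with values here, no pair of measured compounds differs in only one place, so no measured step is available to lean on. The change gives compound 4 the same chain end that compound 2 and compound 3 carry, and both of those were recorded as not active. The step from compound 1 to compound 4 is therefore expected to be small, downward if anything, and likely within the scatter: a number 5.3 percentage points lower from compound 1 to compound 4 (within the scatter). For compound 4 the expected value is 5%, estimated to lie between -5% and 18%.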

Compound 4, a percentage reported as inhibition, at one concentration (the size of the read-out at that concentration, not a potency): 4.32%
Compound 4: middle estimate off by 0.7 percentage points, on the high side; measured number inside the range.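

Going by these compounds alone, this is the first step in the set that changes one place only, the charged group on a saturated chain carbon, seven bonds along the chain from an oxygen on an aromatic ring. In this assay, there is a number 6 percentage points lower from compound 1 to compound 4 (within the scatter), so this read-out does not separate the two-ring group from the five-membered ring. No measurement shown here bears on why the swap leaves the reading within the scatter.

From the compounds shown here alone, whether a morpholine ring, a dimethylamino group or a carboxylic acid in the same place, or a longer chain, would give a clearly larger reading remains open. Going by these compounds, compound 2 and compound 3 have no number, so steps involving them cannot be read, and the effect of where the side chain sits on the aromatic ring stays unknown.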